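The source may hold more compounds than are shown below. What is called first, only, known or untested is meant among the compounds shown, and "the series" means these compounds.

Three compounds have been measured in a functional assay on HEK293 cells for agonist activity at Free fatty acid receptor 1 (Homo sapiens), read by fluorescence and calcium flux, with a stated time of 10 min; a higher number here means that more compound is needed for the effect, a lower number that less compound is needed:

compound 1 `COc1ccc2c(c1)OC(COc1ccc(CCC(=O)O)c(F)c1)CO2` gives 1470 nM
compound 2 `O=C(O)CCc1ccc(OCC2COc3ccc(Br)cc3O2)cc1F` gives 2240 nM
compound 3 `CCOC(CC(=O)O)c1ccc(OCC2COc3ccc(Cl)cc3O2)cc1` gives 640 nM

Compound 3 stands lowest of the three numbers in this assay; compound 1 lies nearest, with a number beyond the scatter above it, and compound 2 lies furthest. For the measured compounds named here, the one step between compounds differing in a single place, a 1.5-fold higher number from compound 1 to compound 2 (0.18 log units; within the scatter), concerns a ring substituent on the shared core and not the chain carbon.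

Compound 4 `O=C(O)CC(c1ccc(OCC2COc3ccc(Cl)cc3O2)cc1)c1cnco1` differs from compound 3 by 1,3-oxazol-5-yl in place of ethoxy on a saturated chain carbon bound to an aromatic carbon and a saturated chain carbon. Going by the values given here, no measured step touches this position or this kind of exchange, so the direction of the change in this assay cannot be read from the data; the only guide is the number of compound 3 itself. The estimate for compound 4 in this assay is therefore 600 nM, with a wide range from 150 nM to 2400 nM. This estimate means a step of a 1.1-fold lower number from compound 3 to compound 4 (0.03 log units; within the scatter), expected to stay within the scatter.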

Compound 4, half-maximal effective concentration: 1030 nM
The estimate for compound 4 lay 1.7-fold (0.23 log units) below the measured number, and the stated range covers the measured number.
By their numbers in this assay, from the lowest: compounds 3, 4, 1 and 2 (each within the scatter of the next, the first and the last beyond it).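

In this assay, for the compounds shown here, the exchange of ethoxy for 1,3-oxazol-5-yl on the saturated chain carbon bound to an aromatic carbon and a saturated chain carbon (a 1.6-fold higher number from compound 3 to compound 4 (0.21 log units; within the scatter)) gives the first reading at this position, which the earlier step on the ring substituent did not touch. Replacing a group with no ring by one five-membered aromatic ring with 2 hetero atoms leaves the number within the scatter, so for this one pair the change in group does not show up as a clear shift. No measured evidence bears on this result.

The compounds shown leave open whether an amine, a phenyl ring or a longer alkoxy chain on this carbon would behave the same way. They also leave open whether 1,3-oxazol-5-yl would give a similar step with methoxy or bromo on the shared core instead of chloro.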